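Cytotoxicity of a third benzyl variant on a shared core

The source may report more compounds than this note shows. Statements on the series, on what has been measured and on what is new or still open speak of the compounds shown alone.

Compound 1 `Cc1cc(/C=C2\SC(=S)N(Cc3ccc(C(F)(F)F)cc3)C2=O)c(C)n1-c1ccc(O)c(C(=O)O)c1`: 45900 nM
Compound 2 `Cc1cc(/C=C2\SC(=S)N(Cc3cccc(Br)c3)C2=O)c(C)n1-c1ccc(O)c(C(=O)O)c1`: 48200 nM

Both numbers come from an ADME assay on MT2 cells (Homo sapiens) for cytotoxicity, read by XTT assay, with a stated time of 4 days; a higher number here means that more compound is tolerated, a lower number that less compound is tolerated. Compound 2 and compound 1 stand together: the step of a 1.1-fold higher number from compound 1 to compound 2 (0.02 log units; within the scatter) lies within the scatter, so neither compound is set apart. Compound 3 `Cc1cc(/C=C2\SC(=S)N(Cc3cccc(C(=O)O)c3)C2=O)c(C)n1-c1ccc(O)c(C(=O)O)c1` is the next variant: carboxy in place of bromo on an aromatic carbon. Going by the values given here, the only measured step also exchanged one aromatic group for another on the same carbon and left the number within the scatter, so the change from compound 2 to compound 3 is estimated at a 1.1-fold higher number from compound 2 to compound 3 (0.06 log units; within the scatter), nothing beyond the scatter. Compound 3 is therefore expected to give about 55000 nM in this assay, between 28000 nM and 110000 nM.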

Compound 3, half-maximal cytotoxic concentration: > 100000 nM
Compound 3: a limit, no number; the forecaster's own chance of this, stated with the estimate: 25%; at least 1.8-fold (0.25 log units) between middle value and limit.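

Going from 3-bromobenzyl to 3-carboxybenzyl gives an at least 2.0-fold higher number from compound 2 to compound 3 (0.31 log units; beyond the scatter), so this position can shift the tolerated concentration beyond the scatter, which the earlier pair did not show. Exchanging 4-(trifluoromethyl)phenyl for 3-carboxyphenyl gives an at least 2.1-fold higher number from compound 1 to compound 3 (0.33 log units; beyond the scatter). Compound 3 gives a limit and not a number, so both steps are minimum sizes: the limit of > 100000 nM in this assay, at which 1 of the 3 values shown sits.

On these data alone, how far the true value of compound 3 lies past that limit stays open. Whether an amine or an amide on the same aromatic carbon would also raise the number is open too.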